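The compounds below may be only part of what the source reports. "The series", "measured", "known", "first", "only" and "open" are said of these compounds alone.

Measured compounds in a physicochemical assay for lipophilicity, at pH 7.4; a lower number here means a more polar compound, a higher number a more lipophilic compound:
- compound 1 `CNC(=O)c1cc(C(=O)NCCC2CCOCC2)cn(Cc2ccccc2)c1=O`, 3.6
- compound 2 `CNC(=O)c1cc(C(=O)NC2CCC2)cn(Cc2cccnc2)c1=O`, 1.8
- compound 3 `CNC(=O)c1cc(C(=O)NC2CC2)cn(Cc2ccc3nc[nH]c3c2)c1=O`, 1.2

Compound 3 stands lowest of the three numbers in this assay. Its nearest neighbour is compound 2, which lies higher by a gap beyond the scatter; compound 1 lies furthest above it, again beyond the scatter. The three share a core and differ in the amide substituent and in the group on the saturated chain carbon bound to an aromatic nitrogen.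

Compound 4 `CNC(=O)c1cc(C(=O)NC2CC2)cn(Cc2cccc3[nH]ccc23)c1=O` is not yet measured in this assay. It differs from compound 3 in one place: 1H-indol-4-yl in place of 1H-benzimidazol-6-yl on a saturated chain carbon bound to an aromatic nitrogen. The leaving group carries one hydrogen-bond acceptor, the entering group none; both carry one hydrogen-bond donor and nine heavy atoms. Within the data shown here, no step between measured compounds isolates this change, so the expectation rests on the structural difference alone. An upward step beyond the scatter is expected, estimated as a number 1.00 log units higher from compound 3 to compound 4 (beyond the scatter). Compound 4 is expected at 2.2 in this assay, within a range of 1.7 to 2.7.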

Compound 4, distribution coefficient: 2.9
Compound 4: middle estimate off by 0.70 log units, on the low side, and the stated range ends below it.
By their numbers in this assay, from the lowest: compound 3; then compound 2; then compound 4; then compound 1.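

In this assay, among these compounds, the first comparison that isolates one place gives a number 1.70 log units higher from compound 3 to compound 4 (beyond the scatter), for 1H-indol-4-yl in place of 1H-benzimidazol-6-yl on a saturated chain carbon bound to an aromatic nitrogen. The exchange leaves the heavy-atom and hydrogen-bond donor counts unchanged and drops the one hydrogen-bond acceptor, so this position can carry a large step with no change in either count. No measurement at hand bears on the origin of this step.

On these data alone, the two groups differ both in ring atoms and in point of attachment, so the share of each in the step stays open. A 1H-indol-6-yl group at this place would separate the two, while an amine or a carboxylic acid there would test how far the number can move.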